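Swapping the furan ring of compound 3 for imidazole

This account rests on a few compounds, and the source may have more. Where it says the series, first, only, none or still open, it means among the compounds named here.

Measured in an assay on CHO cells for antagonist activity at transient receptor potential cation channel subfamily V member 1 (Homo sapiens), read by FLIPR; a lower number here means a stronger inhibitor, a higher number a weaker inhibitor:
- compound 1 `CC(C(=O)NCc1ccc(C(F)(F)F)nc1-c1ccccc1F)c1ccc(NS(C)(=O)=O)c(F)c1` gives 63.3 nM
- compound 2 `COc1ccc(-c2nc(C(F)(F)F)ccc2CNC(=O)C(C)c2ccc(NS(C)(=O)=O)c(F)c2)cc1OC` gives 25.6 nM
- compound 3 `CC(C(=O)NCc1ccc(C(F)(F)F)nc1-c1ccoc1)c1ccc(NS(C)(=O)=O)c(F)c1` gives 1.4 nM

Compound 3 stands lowest of the three numbers in this assay, the step of a 45-fold lower number from compound 1 to compound 3 (1.66 log units; beyond the scatter) and the step of an 18-fold lower number from compound 2 to compound 3 (1.26 log units; beyond the scatter) both lying beyond the scatter, while the step of a 2.5-fold lower number from compound 1 to compound 2 (0.39 log units; beyond the scatter) is modest. Compound 4 `CC(C(=O)NCc1ccc(C(F)(F)F)nc1-n1ccnc1)c1ccc(NS(C)(=O)=O)c(F)c1` differs from compound 3 in one place: 1H-imidazol-1-yl in place of furan-3-yl on an aromatic carbon. Going by the values given here, only the steps into compound 3 bear on this change, and they show that the identity of the ring at this position moves the number by a large amount. Because an 18-fold lower number from compound 2 to compound 3 (1.26 log units; beyond the scatter) favours the five-membered ring, compound 4 is expected to stay fairly close to compound 3, with a modest rise, a 3.6-fold higher number from compound 3 to compound 4 (0.55 log units; beyond the scatter). Compound 4 is estimated at 5 nM, with a range from 1.5 nM to 25 nM.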

Compound 4, inhibition constant: 36.1 nM
The estimate for compound 4 lay 7.2-fold (0.86 log units) below the measured number; the whole stated range lies below it.
By their numbers in this assay, from the lowest: compound 3; then compounds 2, 4 and 1 (each within the scatter of the next, the first and the last beyond it).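

In this assay, a five-membered aromatic ring at this position does not by itself give the low number of compound 3: 1H-imidazol-1-yl has the same ring size and heavy-atom count as furan-3-yl, yet the change gives a 26-fold higher number from compound 3 to compound 4 (1.41 log units; beyond the scatter) and removes nearly all of the advantage of furan-3-yl. The imidazole instead falls level with the two substituted phenyl compounds, with a 1.4-fold higher number from compound 2 to compound 4 (0.15 log units; within the scatter) and a 1.8-fold lower number from compound 1 to compound 4 (0.24 log units; within the scatter) in this comparison. No supporting measurement here accounts for the gap between the two five-membered rings.

This change alters the hetero atoms and the ring's point of attachment together, so their contributions cannot be separated. On these data alone, a thiophen-3-yl or pyrrol-1-yl ring would address what remains open.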